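Aryl ether exchange at the spiro core: compound 4

The source may report more compounds than this note shows. Statements on the series, on what has been measured and on what is new or still open speak of the compounds shown alone.

Compound 2 `NC1=NC2(CCOCC2)N(OCCCOc2cc(Cl)c(Cl)cc2Cl)C(N)=N1` gives 2750 nM in a functional assay on HCT-116 cells (Homo sapiens) for antiproliferative activity, read by MTT assay, with a stated time of 72 h; on this read-out lower numbers stand for stronger inhibition and higher numbers for weaker inhibition. Among the three measured compounds it stands second highest; its nearest neighbour is compound 1 `NC1=NC2(CCOCC2)N(OCCCOc2ccc(F)cc2)C(N)=N1`, which gives 3280 nM, and the gap between the two lies within the scatter. Furthest away is compound 3 `NC1=NC2(CCSCC2)N(OCCCOc2cccc(Cl)c2Cl)C(N)=N1`, which gives 1 nM; compound 3 differs from compound 2 in two places, so its number is only set beside that of compound 2 without a counted step. Compound 4 `NC1=NC2(CCOCC2)N(OCCCOc2ccc(Cl)cc2)C(N)=N1` is not yet measured and differs from compound 2 in one place: 4-chlorophenyl in place of 2,4,5-trichlorophenyl on an oxygen on a saturated carbon. Going by the values given here, the only measured step that bears on this is a 1.2-fold lower number from compound 1 to compound 2 (0.08 log units; within the scatter), where a different exchange of the aryl group on the same oxygen left the number essentially unchanged. Compound 4 carries a 4-chlorophenyl, a halogenated phenyl as do compound 1 and compound 2. No step beyond the scatter is therefore expected. The expected step is a 1.1-fold higher number from compound 2 to compound 4 (0.04 log units; within the scatter). Compound 4 is estimated at 3000 nM, within 1400 nM to 6500 nM.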

Compound 4, half-maximal inhibitory concentration: 690 nM
Beside the measured number, compound 4's estimate is 4.3-fold (0.64 log units) above it; measured number outside the range, below it.
By their numbers in this assay, from the lowest: compound 3; then compound 4; then compounds 2 and 1 (each within the scatter of the next).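

The aryl group on this oxygen is not a silent position in this assay, as the first exchange alone suggested: removing chlorines from the ring gives a 4.0-fold lower number from compound 2 to compound 4 (0.60 log units; beyond the scatter), a step beyond the scatter. A single halogen exchange also registers, with chloro in place of fluoro on an aromatic carbon giving a 4.8-fold lower number from compound 1 to compound 4 (0.68 log units; beyond the scatter), so 4-chlorophenyl stands apart from both 4-fluorophenyl and 2,4,5-trichlorophenyl, whose own numbers lie within the scatter of each other. No measurement at hand accounts for either step.

From the compounds shown here alone, whether a bromo, methyl or methoxy group in place of the chloro on the aromatic carbon would hold or extend this step remains open. So does the effect of 4-chlorophenyl on the core of compound 3.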